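Fluorine on the pendant phenyl and microsomal stability

The source may report more compounds than this note shows. Statements on the series, on what has been measured and on what is new or still open speak of the compounds shown alone.

The set rests on one shared core carrying a pendant phenyl ring, read out in an ADME assay on microsomes from liver (Mus musculus) for metabolic stability, with a stated time of 10 min, tested at 0.5 uM; a higher number here means that more of the compound is left, a lower number that less of the compound is left. Compound 1 `Cc1onc(-c2ccccc2)c1[C@@H]1C[C@@](C)(c2ccc(F)cc2F)N=C(N)S1` gives 12%. Compound 2 `Cc1onc(-c2ccc(F)cc2)c1[C@@H]1C[C@@](C)(c2ccc(F)cc2F)N=C(N)S1` differs from compound 1 by fluoro in place of hydrogen on an aromatic carbon, and in this assay compound 2 gives 23%. That change made a number 11 percentage points higher from compound 1 to compound 2 (beyond the scatter).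

Compound 3 `Cc1noc(-c2ccccc2)c1[C@@H]1C[C@@](C)(c2ccc(F)cc2F)N=C(N)S1` carries the same atoms as compound 1, joined differently; the difference between the two cores is not broken down here. In this assay compound 3 gives 6%, and the values of compound 3 and compound 1 lie within the scatter of each other, whereas compound 2 stands beyond the scatter above compound 3.

Compound 4 `Cc1noc(-c2ccc(F)cc2)c1[C@@H]1C[C@@](C)(c2ccc(F)cc2F)N=C(N)S1` has not yet been measured. It differs from compound 3 by fluoro in place of hydrogen on an aromatic carbon, the same change that separates compound 2 from compound 1, made at the same place. Among the measured compounds shown here, on the single earlier instance, the step from compound 1 to compound 2 of a number 11 percentage points higher from compound 1 to compound 2 (beyond the scatter), the step from compound 3 to compound 4 is expected to be of similar size, about a number 8 percentage points higher from compound 3 to compound 4 (within the scatter), although one prior step on a differently joined core is a thin basis and the gap may well fall inside the scatter. For compound 4 the value in this assay is accordingly estimated at 14%, with a plausible range from 5% to 26%.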

Compound 4, percent of the compound remaining: 53%
For compound 4 the middle estimate is 39 percentage points below the measured one; measured number above the stated range.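

The change from phenyl to 4-fluorophenyl raised the read-out in this assay on both cores, and on the core of compound 3 it gave a number 47 percentage points higher from compound 3 to compound 4 (beyond the scatter), so the direction carried over from one core to the other while the size did not: the same change on two cores in this assay, a number 11 percentage points higher (beyond the scatter) from compound 1 to compound 2 and a number 47 percentage points higher (beyond the scatter) from compound 3 to compound 4, 36 percentage points apart, beyond the scatter of two such steps

Within this series, then, the step measured on one core could not be taken as the measure of the step on the other, even though both pairs point the same way. Two pairs give no reason for the gap between the steps, and they do not show how the same change would behave on any third core.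

The compounds shown leave open whether the gain in this assay belongs to the fluoro group in particular, or whether another group on an aromatic carbon at the same place on the pendant ring, such as chloro, methoxy or a nitrile, would bring a gain of similar size on either core. They also leave open whether the two cores would still part so widely if the methyl group on the five-membered ring carrying the pendant phenyl gave way to an ethyl group or a longer chain.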